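The source may report more compounds than this note shows. Statements on the series, on what has been measured and on what is new or still open speak of the compounds shown alone.

Measured so far:
- compound 1, `CCC(CC)Nc1nc(C)nc2c(-c3cc(F)c(OC)cc3Cl)c(C)nn12`: 1 nM
- compound 2, `CCC1CCCCN1c1nc(C)nc2c(-c3c(C)cc(OC)cc3OC)c(C)nn12`: 3.26 nM
- compound 3, `CCC(CC)Nc1nc(C)nc2c(-c3ccc(OC)cc3)c(C)nn12`: 3.8 nM

All three were run in an assay on cell membranes for displacement of a labelled ligand from corticotropin-releasing factor receptor 1 (Rattus norvegicus); on this read-out lower numbers stand for stronger inhibition and higher numbers for weaker inhibition. Compound 1 gives 1 nM, compound 2 gives 3.26 nM and compound 3 gives 3.8 nM. On these numbers compound 2 stands second highest of the three; its value and that of compound 3 lie within the scatter of each other, while compound 1 sits beyond the scatter on the lower side.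

The next compound is compound 4, `CCC(CC)Nc1nc(C)nc2c(-c3c(C)cc(OC)cc3OC)c(C)nn12`. It differs from compound 2 in one place: (pentan-3-yl)amino in place of 2-ethylpiperidin-1-yl on an aromatic carbon. The same (pentan-3-yl)amino group is carried by compound 1 and compound 3, each paired with a different aryl group, and both give numbers in the same low range as compound 2. Among the compounds with values here, no pair of measured compounds shows this exact exchange on a shared aryl group, so the step cannot be read directly from the data.

Given that compound 1 sits at 1 nM and compound 3 sits at 3.8 nM with the entering group, compound 4 is expected to land in the same range. For compound 4 the expected step is a 1.6-fold lower number from compound 2 to compound 4 (0.21 log units; within the scatter), which is small and not clearly beyond the scatter. The estimate for compound 4 in this assay is 2 nM, with a likely range from 0.7 nM to 6 nM.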

Compound 4, half-maximal inhibitory concentration: 5 nM
Compound 4: middle estimate off by 2.5-fold (0.40 log units), on the low side; measured number inside the range.
By their numbers in this assay, from the lowest: compound 1; then compounds 2, 3 and 4 (each within the scatter of the next).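

In this assay, within the data shown here, the exchange of 2-ethylpiperidin-1-yl for (pentan-3-yl)amino, on the aromatic carbon between two ring nitrogen atoms, gives a 1.5-fold higher number from compound 2 to compound 4 (0.19 log units; within the scatter) and is the first direct reading of this position on a shared aryl group. With this aryl group, the position holds either the ring-bearing group, with 0 hydrogen-bond donors, or the open-chain group, with 1 hydrogen-bond donor, and the read-out does not separate them, so this pair shows no need for either the ring or the amine hydrogen. No measurement bearing on the reason for this result is available.

From the compounds shown here alone, the exchange has been read on one aryl group only, and the matching step on the aryl groups of compound 1 and compound 3 cannot be read, so whether the two groups also stay within the scatter there remains open. Also open, going by these compounds, is how this position responds to groups further from these two, such as a morpholine ring, a small isopropylamino chain or a longer chain carrying a carboxylic acid.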